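The compounds below may be only part of what the source reports. "The series", "measured", "known", "first", "only" and "open" are said of these compounds alone.

Three compounds have been measured in a functional assay, with a stated time of 10 min; a higher number here means a weaker inhibitor, a lower number a stronger inhibitor:

Compound 1 `CCCCCCCCOc1cc(OC)c(Br)cc1C(C)=O` gives 38100000 nM.
Compound 2 `CCCCCCCCCCOc1cc(OC)c(Br)cc1C(C)=O` gives 29700000 nM.
Compound 3 `CCCCCCCCOc1cc(OC)ccc1C(C)=O` gives 69400000 nM.

All three numbers are very high, so none of these compounds is a strong inhibitor. Compound 2 differs from compound 1 by ethyl in place of hydrogen on a saturated chain carbon, eight bonds along the chain from an oxygen on an aromatic ring, and that step came out as a 1.3-fold lower number from compound 1 to compound 2 (0.11 log units; within the scatter). Compound 3 differs from compound 1 only in the core, where the difference is hydrogen in place of bromo on an aromatic carbon, and that step was a 1.8-fold higher number from compound 1 to compound 3 (0.26 log units; within the scatter). Compound 3 stands within the scatter of compound 1, while its gap to compound 2 lies beyond the scatter.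

Compound 4 `CCCCCCCCCCOc1cc(OC)ccc1C(C)=O` has not yet been measured in this assay. It differs from compound 3 by ethyl in place of hydrogen on a saturated chain carbon, eight bonds along the chain from an oxygen on an aromatic ring, which is the same change as the one from compound 1 to compound 2, made at the same place along the chain; only the core differs, as described above. Because that earlier step was a 1.3-fold lower number from compound 1 to compound 2 (0.11 log units; within the scatter), the expectation for compound 4 is a similarly small step, estimated as a 1.3-fold lower number from compound 3 to compound 4 (0.12 log units; within the scatter), with the direction uncertain since the earlier step sits within the scatter. The estimated value for compound 4 is therefore 53000000 nM, expected to fall between 25000000 nM and 115000000 nM.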

Compound 4, half-maximal inhibitory concentration: 57400000 nM
The estimate for compound 4 lay 1.1-fold (0.03 log units) below the measured number; measured number inside the range.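

In this assay, putting ethyl in place of hydrogen on the chain gave a 1.2-fold lower number from compound 3 to compound 4 (0.08 log units; within the scatter) on the core without bromo, a step of about the same size as on the core with bromo: the same change on two cores in this assay, a 1.3-fold lower number (0.11 log units; within the scatter) from compound 1 to compound 2 and a 1.2-fold lower number (0.08 log units; within the scatter) from compound 3 to compound 4, 1.1-fold (0.03 log units) apart, within the scatter of two such steps

Hydrogen in place of bromo on the aromatic carbon likewise gave a 1.9-fold higher number from compound 2 to compound 4 (0.29 log units; within the scatter) with the longer chain, matching what it gave with the shorter chain: the same change on two cores in this assay, a 1.8-fold higher number (0.26 log units; within the scatter) from compound 1 to compound 3 and a 1.9-fold higher number (0.29 log units; within the scatter) from compound 2 to compound 4, 1.1-fold (0.03 log units) apart, within the scatter of two such steps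

So each change carried over from one core to the other here, but every one of these steps lies within the scatter, which means the agreement is between small steps that cannot be told from repeat-measurement noise, and it rests on a single set of four compounds, so it shows neither that either change has a real effect on its own nor that it would carry over to other cores.

The compounds shown leave open whether an amine or a carboxylic acid at the end of the chain, or a much longer chain, would move the number beyond the scatter. They also leave open whether chloro or a nitrile in place of bromo would do so.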